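Two Fluorines in Place of a Methyl: An Estimate

The compounds below may be only part of what the source reports. "The series", "measured", "known", "first", "only" and "open" are said of these compounds alone.

Of the compounds shown here, three have been tested in a functional assay on the whole organism for inhibition, with Mythimna separata as the target, with a stated time of 5 days; a lower number here means that less compound is needed, a higher number that more compound is needed for the effect. Among the compounds with values here, compound 1 `Cc1ccc(-c2nnc(COc3cnn(C(C)(C)C)c(=O)c3Cl)o2)cc1` gives 19900 nM and is the only one with a measured number. Compound 2 `CCCCn1ncc(OCc2nnc(-c3ccccc3)o2)c(Cl)c1=O` returns only the assay limit, > 299000 nM. Compound 3 `CC(C)(C)n1ncc(OCc2nnc(-c3cc(F)c(Cl)c([N+](=O)[O-])c3Cl)o2)c(Cl)c1=O` likewise returns a limit, > 299000 nM. Compound 1 thus stands apart from the limit of > 299000 nM in this assay, at which 2 of the 3 values shown sit. Compound 4 `CC(C)(C)n1ncc(OCc2nnc(-c3c(F)cccc3F)o2)c(Cl)c1=O` has not yet been measured; it differs from compound 1 by 2,6-difluorophenyl in place of 4-methylphenyl on an aromatic carbon, in words 2,6-difluorophenyl in place of 4-methylphenyl on an aromatic carbon. Within the data shown here, no measured pair isolates this change, and the two limits give no direction. The expected step from compound 1 to compound 4 in this assay is a modest loss, a 2.0-fold higher number from compound 1 to compound 4 (0.30 log units; within the scatter), inside a wide band. Compound 4 is therefore estimated at about 40000 nM, between 8000 nM and 200000 nM.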

Compound 4, half-maximal effective concentration: 45400 nM
Compound 4: the middle estimate sits 1.1-fold (0.05 log units) below what was measured, within the range that was stated.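

In this assay, the aromatic carbon that carries this ring accepts 2,6-difluorophenyl in place of 4-methylphenyl at a modest cost: a 2.3-fold higher number from compound 1 to compound 4 (0.36 log units; beyond the scatter). Within the data shown here, this is the first direct reading of a change at this position, and compound 4 still returns a measured number. Compound 2 and compound 3 stop at a limit of the assay, not a number: the limit of > 299000 nM in this assay, at which 2 of the 4 values shown sit.

A single step cannot separate losing the methyl from gaining the two fluorines. The compounds shown also leave open how a phenyl bearing an amine or a methoxy group would fare here.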